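Cyclopentylamino for methyl: expectation for compound 4

The source may hold more compounds than are shown below. What is called first, only, known or untested is meant among the compounds shown, and "the series" means these compounds.

The series shares one core carrying a halogen or a tert-butyl group on an aromatic carbon. Compound 1 `Cc1cccnc1-c1ccc(C(=O)Nc2ccc(F)cc2)cc1` is the fluoro member, compound 2 `Cc1cccnc1-c1ccc(C(=O)Nc2ccc(Cl)cc2)cc1` the chloro member and compound 3 `Cc1cccnc1-c1ccc(C(=O)Nc2ccc(C(C)(C)C)cc2)cc1` the tert-butyl member. In a functional assay for antagonist activity at transient receptor potential cation channel subfamily V member 1 (Homo sapiens), read by FLIPR (on this read-out lower numbers stand for stronger inhibition and higher numbers for weaker inhibition), compound 1 reaches only the limit > 4000 nM, not a number; it is the limit noted as the limit of > 4000 nM in this assay, at which 1 of the 3 values shown sits. In this assay compound 2 gives 1500 nM and compound 3 gives 11 nM. The steps run an at least 2.6-fold lower number from compound 1 to compound 2 (0.42 log units; beyond the scatter), an at least 360-fold lower number from compound 1 to compound 3 (2.56 log units; beyond the scatter) and a 140-fold lower number from compound 2 to compound 3 (2.13 log units; beyond the scatter). Compound 3 thus holds the lowest of the two numbers in this assay, with compound 2 the nearest at a distance beyond the scatter.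

Compound 4 `CC(C)(C)c1ccc(NC(=O)c2ccc(-c3ncccc3NC3CCCC3)cc2)cc1` differs from compound 3 in one place: cyclopentylamino in place of methyl on an aromatic carbon. For the measured compounds named here, none of the measured steps touches this position; all three vary the group on the other aromatic carbon, so no measured step bears directly on the change, and the expectation rests on compound 3 alone, with its 11 nM as the anchor. The step is expected to stay near the scatter, a 1.8-fold higher number from compound 3 to compound 4 (0.26 log units; within the scatter), with wide uncertainty. For compound 4 in this assay the estimate is 20 nM, in the range 3 nM to 150 nM.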

Compound 4, half-maximal inhibitory concentration: 190 nM
Compound 4: middle estimate off by 9.5-fold (0.98 log units), on the low side; the whole stated range lies below it.
By their numbers in this assay, from the lowest: compound 3; then compound 4; then compound 2. At a limit, above all of these: compound 1.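

Until now, only the group on the other aromatic carbon had varied, so this position had no reading of its own. In this assay, cyclopentylamino in place of methyl, on an aromatic carbon two atoms from the ring nitrogen and ortho to a large group, gives a 17-fold higher number from compound 3 to compound 4 (1.24 log units; beyond the scatter) and so shows that the series answers strongly to a change at this position. The step exchanges methyl for a group that adds a five-membered ring, a nitrogen, a hydrogen-bond donor and a hydrogen-bond acceptor all at once, and nothing measured here bears on which of these accounts for it.

The compounds shown leave open whether the higher number goes with the ring or with the nitrogen link, a question that cyclopentyl, cyclopentyloxy or the smaller methylamino at the same position could separate. They also leave open whether a plain amine or a longer chain such as butylamino would follow cyclopentylamino, and whether a step of this size would recur with chloro in place of tert-butyl on the other aromatic carbon.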